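Swapping the nitro group for an ethoxycarbonyl group

This account rests on a few compounds, and the source may have more. Where it says the series, first, only, none or still open, it means among the compounds named here.

Compound 1 `CN1CCN(c2nc3cc([N+](=O)[O-])ccc3o2)CC1` carries a nitro group on its core. In a functional assay on ileum (strain Hartley) for agonist activity at 5-hydroxytryptamine receptor 3A (Cavia porcellus) (a lower number here means a less potent compound, a higher number a more potent compound, by a factor of ten per unit of this negative logarithm), compound 1 gives 6.1. Among the measured compounds shown here, compound 2 `COc1cc(Cl)cc2nc(N3CCN(C)CC3)oc12` is the only other compound measured so far; in this assay compound 2 gives 6.16, and the two values sit within the usual scatter of each other, so compound 1 stands level with compound 2 rather than apart from it. Compound 3 `CCOC(=O)c1ccc2oc(N3CCN(C)CC3)nc2c1` has not been measured yet; it differs from compound 1 in one place: ethoxycarbonyl in place of nitro on an aromatic carbon. For the measured compounds named here, no measured pair shows what this exchange does, so the expectation rests on compound 1 alone, and the most plausible outcome is a step that stays within the scatter. The estimate for compound 3 in this assay is 6.2, with a range from 5.5 to 6.9. This estimate means an expected step of a number 0.10 log units higher from compound 1 to compound 3 (within the scatter).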

Compound 3, negative logarithm of the half-maximal effective concentration: < 4
Compound 3: only a limit was reported; the forecaster's own chance of this, stated with the estimate: 5%; middle value at least 2.20 log units away from the limit.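

In this assay compound 3 gives < 4, which is a limit of the assay and not a number. Exchanging nitro for ethoxycarbonyl gives a number at least 2.10 log units lower from compound 1 to compound 3 (beyond the scatter), so this aromatic carbon does not accept every group, even though the two groups match in their counts of hydrogen-bond donors and acceptors and differ in heavy atoms, with ethoxycarbonyl the larger. The step can therefore be read only as a limit, and its full size stays unknown: the limit of < 4 in this assay, at which 1 of the 3 values shown sits.

The compounds shown leave open whether the drop follows from the ethyl chain, which adds to the heavy-atom count, or from the ester as a whole. A carboxylic acid, a methyl ester or a nitrile on the same carbon would help to separate these two readings.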